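Heteroaryl replacements at the benzylic carbon of the series

The source may report more compounds than this note shows. Statements on the series, on what has been measured and on what is new or still open speak of the compounds shown alone.

Measured compounds:
compound 1, `CC#CC(CC(=O)O)c1ccc(OCC2COc3ccc(Cl)cc3O2)cc1`, 100 nM
compound 2, `O=C(O)CC(c1ccc(OCC2COc3ccc(Cl)cc3O2)cc1)c1cnco1`, 1030 nM
compound 3, `Cn1ccnc1C(CC(=O)O)c1ccc(OCC2COc3ccc(Cl)cc3O2)cc1`, 5880 nM

All three were tested in a functional assay on HEK293 cells for agonist activity at Free fatty acid receptor 1 (Homo sapiens), read by fluorescence and calcium flux, with a stated time of 10 min; a lower number here means that less compound is needed, a higher number that more compound is needed for the effect. Compound 3 stands highest of the three numbers: the nearest, compound 2, lies a 5.7-fold higher number from compound 2 to compound 3 (0.76 log units; beyond the scatter) below it, and compound 1 lies a 59-fold higher number from compound 1 to compound 3 (1.77 log units; beyond the scatter) below it. Compound 4, `Cn1nncc1C(CC(=O)O)c1ccc(OCC2COc3ccc(Cl)cc3O2)cc1`, differs from compound 3 only by 1-methyl-1H-1,2,3-triazol-5-yl in place of 1-methyl-1H-imidazol-2-yl on a saturated chain carbon bound to an aromatic carbon and a saturated chain carbon. Among the measured compounds shown here, no measured step exchanges one five-membered heteroaryl for another of this kind; the closest comparison, a 5.7-fold higher number from compound 2 to compound 3 (0.76 log units; beyond the scatter), was a modest rise, and both replacements of the alkyne (a 10-fold higher number from compound 1 to compound 2 (1.01 log units; beyond the scatter), a 59-fold higher number from compound 1 to compound 3 (1.77 log units; beyond the scatter)) raised the number. A step of the size a 1.2-fold higher number from compound 3 to compound 4 (0.08 log units; within the scatter) is therefore expected, possibly within the scatter. Compound 4 is estimated at 7000 nM, range 2000 nM to 25000 nM.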

Compound 4, half-maximal effective concentration: 3870 nM
Beside the measured number, compound 4's estimate is 1.8-fold (0.26 log units) above it, within the range that was stated.
By their numbers in this assay, from the lowest: compound 1; then compound 2; then compounds 4 and 3 (each within the scatter of the next).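

In this assay, the step of a 1.5-fold lower number from compound 3 to compound 4 (0.18 log units; within the scatter) shows no separation of 1-methyl-1H-1,2,3-triazol-5-yl from 1-methyl-1H-imidazol-2-yl at this saturated chain carbon. The step of a 3.8-fold higher number from compound 2 to compound 4 (0.57 log units; beyond the scatter) leaves 1,3-oxazol-5-yl with the lowest number of the three heteroaryl groups shown, and the step of a 39-fold higher number from compound 1 to compound 4 (1.59 log units; beyond the scatter) extends the lead of prop-1-yn-1-yl over them to a third heteroaryl group. Open, from the compounds shown here alone, is whether a cyclopropyl group or a longer alkyne such as but-1-yn-1-yl at this carbon would match the alkyne of compound 1. No measured evidence accounts for any of these steps.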